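Vinyl in place of hydroxymethyl: from compound 2 to compound 3

A few compounds are considered here, and "the series" means these few. Any claim that something is new, unique, unknown or untested is made for them only; others in the source may bear on it.

Compound 1 is `COc1ccc([C@H]2NC(=O)O[C@H]2CO)cc1`; in a functional assay on MCF7 cells (Homo sapiens) for cytotoxicity (on this read-out lower numbers stand for stronger inhibition and higher numbers for weaker inhibition), compound 1 gives 82400 nM.
Compound 2 is `COc1ccc([C@H]2NC(=O)O[C@@H]2CO)cc1`; in this assay compound 2 reaches only a limit of the assay, > 100000 nM.

For the measured compounds named here, only two compounds have been measured, and they share all atoms and bonds. Going by the values given here, the single measured step, an at least 1.2-fold higher number from compound 1 to compound 2 (0.08 log units; that floor lies within the scatter), rests on the fact that compounds 1 and 2 differ only in the configuration as drawn together with the limit of > 100000 nM in this assay, at which 1 of the 2 values shown sits. Compound 2 therefore stands at the upper edge of the numbers seen here, marked by a limit rather than by a value.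

Compound 3, `C=C[C@H]1OC(=O)N[C@@H]1c1ccc(OC)cc1`, carries vinyl in place of hydroxymethyl on a saturated ring carbon. Among the compounds with values here, no measured step touches this group: the only step seen, an at least 1.2-fold higher number from compound 1 to compound 2 (0.08 log units; that floor lies within the scatter), concerns configuration alone and offers no guide to the size or the direction of a change from hydroxymethyl to vinyl. With nothing pointing either way, compound 3 is expected to show a number no higher from compound 2 to compound 3 (the limit leaves the size open). The estimate for compound 3 is 100000 nM, within 40000 nM to 300000 nM, and a limit rather than a number is again thought quite likely.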

Compound 3, half-maximal inhibitory concentration: > 100000 nM
Compound 3 gave a limit, no number; the forecaster's own chance of this, stated with the estimate: 60%; the middle value sits exactly at the limit.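

In this assay compound 3 gives > 100000 nM, a limit of the assay and not a number. For the compounds shown here, compound 2 also stands at a limit, and no step from compound 2 to compound 3 can be read. The compounds shown leave open whether vinyl in place of hydroxymethyl changes the read-out at all, and in which direction.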